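Methyl added to the imidazole of compound 2

This account rests on a few compounds, and the source may have more. Where it says the series, first, only, none or still open, it means among the compounds named here.

Compound 1, `Cc1cc2c(cc1Cc1ccc(-c3cocn3)cc1)C(=O)N([C@H]1CCOC[C@@H]1O)C2`, in an ADME assay on microsomes from liver (Homo sapiens) for metabolic stability (on this read-out higher numbers stand for fast clearance and lower numbers for slow clearance), gives < 8 mL/min/kg, which is a limit of the assay and not a number.
Compound 2, `Cc1cc2c(cc1Cc1ccc(-n3ccnc3)cc1)C(=O)N([C@H]1CCOC[C@@H]1O)C2`, in this assay gives < 8 mL/min/kg, again a limit of the assay.

Compound 2 therefore stands at the lower limit of this assay, and no number is known for it. Among the compounds with values here, the only measured step, a step that the two limits leave unreadable from compound 1 to compound 2, cannot be read in size or direction because both of its ends sit at the limit (the limit of < 8 mL/min/kg in this assay, at which 2 of the 2 values shown sit). Compound 3, `Cc1cn(-c2ccc(Cc3cc4c(cc3C)CN([C@H]3CCOC[C@@H]3O)C4=O)cc2)cn1`, differs from compound 2 by methyl in place of hydrogen on an aromatic carbon. No measured step bears directly on this change, and the one step shown is unreadable. Compound 3 is expected to show a step that the limit leaves unreadable from compound 2 to compound 3 in this assay, which is no step beyond the usual scatter. The estimate for compound 3 is 6 mL/min/kg, with a range from 3 mL/min/kg to 14 mL/min/kg, and a limit is again the most likely report.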

Compound 3, clearance: 30 mL/min/kg
Beside the measured number, compound 3's estimate is 5.0-fold (0.70 log units) below it, and the stated range ends below it.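

In this assay, within the data shown here, methyl in place of hydrogen on this aromatic carbon gives an at least 3.7-fold higher number from compound 2 to compound 3 (0.57 log units; beyond the scatter), the first change here whose direction can be read, as the earlier step between two limits cannot be read. Replacing 1,3-oxazol-4-yl with 4-methyl-1H-imidazol-1-yl gives an at least 3.7-fold higher number from compound 1 to compound 3 (0.57 log units; beyond the scatter), so compound 3 alone among the three has a number. The true size of both steps stays open because compound 1 and compound 2 each give only a limit of the assay, not a number: the limit of < 8 mL/min/kg in this assay, at which 2 of the 3 values shown sit.

Going by these compounds, it remains open whether the rise belongs to methyl itself or would also follow from an ethyl, a hydroxymethyl or a fluorine on the same carbon. On these data alone, it is also open whether a methyl on another carbon of the 1H-imidazol-1-yl ring would give a comparable step.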